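This account rests on a few compounds, and the source may have more. Where it says the series, first, only, none or still open, it means among the compounds named here.

Three compounds share one core and differ only in the aryl group on the carbonyl carbon. Compound 1 `COc1cc(-c2nnc(SCC(=O)c3ccc(Cl)cc3)n2N)cc(OC)c1OC` is reported only as a limit in a functional assay on HepG2 cells (Homo sapiens) for antiproliferative activity, read by MTT assay, with a stated time of 48 h (on this read-out higher numbers stand for weaker inhibition and lower numbers for stronger inhibition), namely > 100000 nM. Compound 2 `COc1cc(-c2nnc(SCC(=O)c3ccc(Br)cc3)n2N)cc(OC)c1OC` gives 92500 nM in this assay. Compound 3 `COc1cc(-c2nnc(SCC(=O)c3ccc(C(F)(F)F)cc3)n2N)cc(OC)c1OC` is again reported only as a limit, > 100000 nM. Compound 3 therefore stands without a number of its own, at the weak end of what is shown; the limit of > 100000 nM in this assay, at which 2 of the 3 values shown sit, covers two of the three entries. The steps seen so far are small or unreadable: an at least 1.0-fold lower number from compound 1 to compound 2 (0.03 log units; that floor lies within the scatter), an at least 1.0-fold higher number from compound 2 to compound 3 (0.03 log units; that floor lies within the scatter), and a step that the two limits leave unreadable from compound 1 to compound 3.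

Compound 4 `COc1cc(-c2nnc(SCC(=O)c3cccc(Br)c3)n2N)cc(OC)c1OC` differs from compound 3 by 3-bromophenyl in place of 4-(trifluoromethyl)phenyl on a carbonyl carbon. The nearest measured step is an at least 1.0-fold higher number from compound 2 to compound 3 (0.03 log units; that floor lies within the scatter). Compound 2 with its 4-bromophenyl gives 92500 nM in this assay. No step beyond the scatter is expected in this assay. Compound 4 is expected at about 95000 nM, with a range from 40000 nM to 200000 nM. The expected step is an at least 1.0-fold lower number from compound 3 to compound 4 (0.02 log units; that floor lies within the scatter), and a limit rather than a number is quite possible.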

Compound 4, half-maximal inhibitory concentration: 56000 nM
The estimate for compound 4 lay 1.7-fold (0.23 log units) above the measured number; the measured number falls inside the stated range.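

In this assay, the 3-bromophenyl group on the carbonyl carbon gives the series a second actual number, and its comparison with the 4-bromophenyl group is a 1.7-fold lower number from compound 2 to compound 4 (0.22 log units; within the scatter), so these two bromophenyl groups are not told apart. Against the two compounds reported only as limits, the steps are an at least 1.7-fold lower number from compound 3 to compound 4 (0.25 log units; that floor lies within the scatter) and an at least 1.7-fold lower number from compound 1 to compound 4 (0.25 log units; that floor lies within the scatter), and these floors do not show that either exchange of aryl group matters. Limits still make up much of the series: the limit of > 100000 nM in this assay, at which 2 of the 4 values shown sit.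

From the compounds shown here alone, whether any aryl group at this place can shift the value beyond the scatter remains open. Going by these compounds, the effect of an amine or a carboxylic acid on the phenyl ring, in place of the halogen or trifluoromethyl, is also open.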